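The source may report more compounds than this note shows. Statements on the series, on what has been measured and on what is new or still open speak of the compounds shown alone.

Measured compounds:
compound 1 `CCOc1ccc2c(=O)c(-c3ccc(O)cc3)coc2c1` with 100% in a functional assay on mitochondria (Cricetulus griseus) for inhibition of Monoamine oxidase (Homo sapiens), tested at 9 uM; a higher number here means a stronger effect of the compound at the concentration tested, a lower number a weaker effect;
compound 2 `O=c1c(-c2ccc(O)cc2)coc2cc(CC3OC(CO)C(O)C(O)C3O)ccc12` with 0% in this assay.

Of the two numbers shown, compound 1 stands highest in this assay; its nearest neighbour, compound 2, lies lower, a gap well beyond the scatter. Among the measured compounds shown here, no step between the two measured compounds is counted, so the pair says only that compound 1 gives full inhibition and compound 2 none at the same concentration.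

Compound 3 `O=c1c(-c2ccc(O)cc2)coc2cc(OCCCCCCBr)ccc12` has not yet been measured. It differs from compound 1 by 4-bromobutyl in place of hydrogen on a saturated chain carbon, two bonds along the chain from an oxygen on an aromatic ring: the ethoxy of compound 1 becomes (6-bromohexyl)oxy, with no ring added and no donor or acceptor gained. Compound 1 already sits at the top of the scale, so the step can only hold or fall. As no change of this kind has been measured here, the expected step is modest, and the estimated move in this assay is a number 25 percentage points lower from compound 1 to compound 3 (beyond the scatter), downward but with wide uncertainty. Compound 3 is therefore expected to give about 75%, in a range from 30% to 100%.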

Compound 3, a percentage reported as inhibition, at one concentration (the size of the read-out at that concentration, not a potency): 95.7%
Estimate against measurement, compound 3: 20.7 percentage points below, and the stated range covers the measured number.
By their numbers in this assay, from the lowest: compound 2; then compounds 3 and 1 (each within the scatter of the next).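

In this assay, replacing ethoxy with (6-bromohexyl)oxy amounts to a number 4.3 percentage points lower from compound 1 to compound 3 (within the scatter) and thus shows that this position, on a saturated chain carbon two bonds along the chain from an oxygen on an aromatic ring, can carry 4-bromobutyl in place of hydrogen without a read-out change beyond the scatter. Among the compounds shown here, neither compound 1 nor compound 2 could show this on its own, and the result gives the first measured change at this chain, with compound 3 standing alongside compound 1 near the top of the scale at the single concentration tested, where a read-out of this kind says nothing about potency. Nothing measured here explains why the longer brominated chain leaves the read-out in place.

The compounds shown leave open whether the hexyl chain or its terminal bromine matters for this result, which an unsubstituted hexyl chain would address, and whether a terminal amine, a carboxylic acid or a longer chain would hold the read-out in this assay as well. They also leave open whether compound 1 and compound 3 would separate at lower concentrations.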